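A Methyl Branch Tried on a Second Core

A few compounds are considered here, and "the series" means these few. Any claim that something is new, unique, unknown or untested is made for them only; others in the source may bear on it.

Measured so far in an assay on membranes from HeLa cells for displacement of a labelled ligand from adenosine receptor A3 (Homo sapiens), read by scintillation counting, with a stated time of 180 min, tested at 1 uM; a lower number here means less inhibition, a higher number more inhibition at the concentration tested (going by the name of the read-out):
Compound 1 `CCCOC(=O)C1=C(C)NC(=O)NC1c1cccs1` gives 32%.
Compound 2 `CC1=C(C(=O)OCC(C)C)C(c2cccs2)NC(=O)N1` gives 11%.
Compound 3 `CCSC(=O)C1=C(C)NC(=O)NC1c1ccsc1` gives 2%.

The change from compound 1 to compound 2 is methyl in place of hydrogen on a saturated chain carbon bound to two saturated chain carbons, and it gave a number 21 percentage points lower from compound 1 to compound 2 (beyond the scatter). Compound 3 has a different core; the difference between the two cores is not broken down here. Its value in this assay sits with compound 2 within the scatter and clearly under compound 1.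

Compound 4 `CC1=C(C(=O)SC(C)C)C(c2ccsc2)NC(=O)N1` is not yet measured. Against compound 3 it carries methyl in place of hydrogen on a saturated chain carbon bound to a saturated chain carbon and a sulfur, the same kind of change as before, but here the carbon is bound to a saturated chain carbon and a sulfur rather than to two saturated chain carbons. Compound 3 already starts very low, so little room to fall remains. Compound 4 is expected to stay low, with an estimated step of a number 1 percentage points higher from compound 3 to compound 4 (within the scatter), resting on the drop seen in a number 21 percentage points lower from compound 1 to compound 2 (beyond the scatter) and on the starting value of compound 3 at 2%. The estimate for compound 4 is 3%, between 0% and 12%.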

Compound 4, a percentage reported as inhibition, at one concentration (the size of the read-out at that concentration, not a potency): 1%
For compound 4 the middle estimate is 2 percentage points above the measured one; the range from low to high includes it.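

In this assay the same methyl addition gave a number 1 percentage points lower from compound 3 to compound 4 (within the scatter) on the second core, so the drop seen on the core of compound 1 did not repeat at its earlier size: the same change on two cores in this assay, a number 21 percentage points lower (beyond the scatter) from compound 1 to compound 2 and a number 1 percentage points lower (within the scatter) from compound 3 to compound 4, 20 percentage points apart, beyond the scatter of two such steps

This does not show that the core alone sets the size of the step. Compound 3 gives only 2% and so leaves almost no room for a fall, and the methyl here sits on a carbon bound to a saturated chain carbon and a sulfur, not on one bound to two saturated chain carbons.

The compounds shown leave open how a longer chain or an amine would read out in this place. They also leave open how the methyl change behaves on the second core from a higher starting value.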